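The compounds below may be only part of what the source reports. "The series", "measured", "known", "first", "only" and "open" are said of these compounds alone.

Of the three compounds measured, compound 3 `O=c1c(-c2cccc([N+](=O)[O-])c2)nc2ccccc2n1Cc1ccc2ccccc2c1` stands highest: in an assay on cells for activation of Cystic fibrosis transmembrane conductance regulator (Homo sapiens), read by fluorescence, with a stated time of 10 min (a lower number here means that less compound is needed, a higher number that more compound is needed for the effect), compound 3 gives 4300 nM, whereas compound 1 `CCn1c(=O)c(-c2cccc([N+](=O)[O-])c2)nc2ccccc21` gives 65 nM and compound 2 `C=CCn1c(=O)c(-c2cccc([N+](=O)[O-])c2)nc2ccccc21` gives 55 nM. Compound 4 `O=c1c(-c2cccc([N+](=O)[O-])c2)nc2ccccc2n1Cc1ccco1` differs from compound 3 by furan-2-yl in place of naphthalen-2-yl on a saturated chain carbon bound to an aromatic nitrogen. Within the data shown here, the steps that bear on this change are those leading into compound 3: a 66-fold higher number from compound 1 to compound 3 (1.82 log units; beyond the scatter) and a 78-fold higher number from compound 2 to compound 3 (1.89 log units; beyond the scatter), while a 1.2-fold lower number from compound 1 to compound 2 (0.07 log units; within the scatter). Both large steps arose when the two six-membered aromatic rings entered; in compound 4 a single five-membered aromatic ring with one hetero atom takes their place. A lower number in this assay is therefore expected for compound 4, corresponding to an 11-fold lower number from compound 3 to compound 4 (1.03 log units; beyond the scatter). The estimate for compound 4 is 400 nM, with a range from 100 nM to 2000 nM.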

Compound 4, half-maximal effective concentration: 20 nM
Compound 4: the middle estimate sits 20-fold (1.30 log units) above what was measured; the measured number lies below the stated range.
By their numbers in this assay, from the lowest: compound 4; then compounds 2 and 1 (each within the scatter of the next); then compound 3.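

At this place, on a saturated chain carbon bound to an aromatic nitrogen, an aromatic ring does not in itself raise the number in this assay: furan-2-yl in place of naphthalen-2-yl gives a 220-fold lower number from compound 3 to compound 4 (2.33 log units; beyond the scatter) and restores the low range. Furan-2-yl also goes modestly past the short chains, with a 2.8-fold lower number from compound 2 to compound 4 (0.44 log units; beyond the scatter) and a 3.3-fold lower number from compound 1 to compound 4 (0.51 log units; beyond the scatter) as the steps from vinyl and methyl. Nothing measured here accounts for the gap between the two ring groups. As far as these compounds go, whether phenyl or thiophen-2-yl sits nearer furan-2-yl or naphthalen-2-yl remains open. So does whether the ring oxygen matters.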